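Swapping phenyl for a pyrrolidinylmethyl arm, opposite handedness

This account rests on a few compounds, and the source may have more. Where it says the series, first, only, none or still open, it means among the compounds named here.

Compound 2 `Cc1n[nH]cc1-c1cc2nc(-c3ccccc3)[nH]c(=O)c2s1` gives 1600 nM in an assay for inhibition of Rho-associated protein kinase 1 (Homo sapiens), read by TR-FRET, with stated times of 5 min and 2 h (a higher number here means a weaker inhibitor, a lower number a stronger inhibitor), the highest of the three numbers shown. Compound 1 `Cc1nc2cc(-c3c[nH]nc3C)sc2c(=O)[nH]1` gives 1500 nM, and the step of a 1.1-fold higher number from compound 1 to compound 2 (0.03 log units; within the scatter) lies within the scatter. Compound 3 `Cc1n[nH]cc1-c1cc2nc(CN3CC[C@@H](C)C3)[nH]c(=O)c2s1` gives 540 nM, reached through a 3.0-fold lower number from compound 2 to compound 3 (0.47 log units; beyond the scatter) and, from compound 1, through a 2.8-fold lower number from compound 1 to compound 3 (0.44 log units; beyond the scatter). Compound 4 `Cc1n[nH]cc1-c1cc2nc(CN3CC[C@H](C)C3)[nH]c(=O)c2s1` carries the same kind of change as compound 3, but with the opposite arrangement at its single stereocentre: (3-methylpyrrolidin-1-yl)methyl in place of phenyl on an aromatic carbon. For the measured compounds named here, the step from compound 2 to compound 3 is the only direct guide, and it was modest. The mirror-image group itself has no measurement, so the range stays wide. Compound 4 is expected to give 650 nM, between 250 nM and 1700 nM, a step of a 2.5-fold lower number from compound 2 to compound 4 (0.39 log units; beyond the scatter).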

Compound 4, half-maximal inhibitory concentration: 420 nM
Compound 4: middle estimate off by 1.5-fold (0.19 log units), on the high side; the measured number falls inside the stated range.
By their numbers in this assay, from the lowest: compounds 4 and 3 (each within the scatter of the next); then compounds 1 and 2 (each within the scatter of the next).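

In this assay the (3-methylpyrrolidin-1-yl)methyl arm keeps its gain with either handedness: replacing phenyl gives a 3.8-fold lower number from compound 2 to compound 4 (0.58 log units; beyond the scatter) and adding 3-methylpyrrolidin-1-yl to the methyl gives a 3.6-fold lower number from compound 1 to compound 4 (0.55 log units; beyond the scatter) at this position. Handedness shows no readable effect, with a 1.3-fold lower number from compound 3 to compound 4 (0.11 log units; within the scatter) as the step, and this pair tests that one feature alone: the fact that compounds 3 and 4 differ only in the configuration as drawn.

Still open, from the compounds shown here alone, is whether a hydroxyl in place of the ring methyl would make handedness count. Also open, going by these compounds, is whether an open-chain diethylaminomethyl arm would hold the gain without the ring.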